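A few compounds are considered here, and "the series" means these few. Any claim that something is new, unique, unknown or untested is made for them only; others in the source may bear on it.

Measured so far:
compound 1 `COC(=O)/C=C/C(=O)N[C@@H](C)Cn1ccc(-c2ccc(C#N)c(Cl)c2)n1` — > 30000 nM
compound 2 `C[C@@H](Cn1ccc(-c2ccc(C#N)c(Cl)c2)n1)Nc1cncnc1` — > 30000 nM

In an ADME assay on PC-3 cells (Homo sapiens) for cytotoxicity, read by CCK-8 assay, with a stated time of 6 days (on this read-out lower numbers stand for stronger inhibition and higher numbers for weaker inhibition), the value of compound 1 is a limit of the assay, not a number. In this assay the value of compound 2 is likewise only a limit. The step that the two limits leave unreadable from compound 1 to compound 2 is therefore of unreadable size. Both values sit at the limit of > 30000 nM in this assay, at which 2 of the 2 values shown sit.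

Compound 3 `C[C@@H](Cn1ccc(-c2ccc(C#N)c(Cl)c2)n1)Nc1nccc(Cl)n1` differs from compound 2 by 4-chloropyrimidin-2-yl in place of pyrimidin-5-yl on an amine nitrogen. For the measured compounds named here, no measured step bears on this change, and the one known step gives no size. The expected step is a number no higher from compound 2 to compound 3 (the limit leaves the size open), none beyond the scatter. Compound 3 is expected at 30000 nM, with a range of 8000 nM to 60000 nM.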

Compound 3, half-maximal inhibitory concentration: > 30000 nM
Compound 3: no number, only a limit (the forecaster's own chance of this, stated with the estimate: 75%); the middle value sits exactly at the limit.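

No step can be read among compound 1, compound 2 and compound 3 in this assay, since all three values are limits of the assay and not numbers: the limit of > 30000 nM in this assay, at which 3 of the 3 values shown sit.

The compounds shown leave open whether any group on the amine nitrogen gives a readable number in this assay.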